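From 2-Fluorophenyl to 4-Fluorophenyl: An Expected Flat Step

This account rests on a few compounds, and the source may have more. Where it says the series, first, only, none or still open, it means among the compounds named here.

In a functional assay on the whole organism for inhibition, with Felis catus as the target, with a stated time of 30 min (a higher number here means that more compound is needed for the effect, a lower number that less compound is needed), compound 1 `OC(CNCCOc1ccc(Cl)cc1)COc1ccccc1` gives 0.08 mg/kg and compound 2 `OC(CNCCOc1ccccc1F)COc1ccccc1` gives 0.081 mg/kg. Within the data shown here, compound 2 therefore stands level with compound 1, the only other compound measured, and the two lie within the scatter of each other. Compound 3 `OC(CNCCOc1ccc(F)cc1)COc1ccccc1` has 4-fluorophenyl in place of 2-fluorophenyl on an oxygen on a saturated carbon. Among the measured compounds shown here, one measured step bears on this change. It is a 1.0-fold higher number from compound 1 to compound 2 (0.01 log units; within the scatter), which exchanges 4-chlorophenyl for 2-fluorophenyl at the same place and stays within the scatter. No direct exchange of the two fluorophenyl groups has been measured, so this evidence is thin. Even so, no step beyond the scatter is expected in this assay, and no direction is favoured. The estimated change is a 1.0-fold lower number from compound 2 to compound 3 (0.01 log units; within the scatter). For compound 3 the expected value is 0.08 mg/kg, within an estimated range of 0.035 mg/kg to 0.18 mg/kg.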

Compound 3, dose for half-maximal effect: 0.029 mg/kg
The estimate for compound 3 lay 2.8-fold (0.44 log units) above the measured number, outside the stated range (below it).
By their numbers in this assay, from the lowest: compound 3; then compounds 1 and 2 (each within the scatter of the next).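

The exchange of 2-fluorophenyl for 4-fluorophenyl on an oxygen on a saturated carbon gives, in this assay, a 2.8-fold lower number from compound 2 to compound 3 (0.45 log units; beyond the scatter), so these two groups are not interchangeable here even though they have the same atoms. Fluoro in place of chloro on an aromatic carbon also counts, with a 2.8-fold lower number from compound 1 to compound 3 (0.44 log units; beyond the scatter), so the level standing of compound 1 and compound 2 did not mean that this group could be exchanged freely. Nothing available explains why compound 3 stands apart from the other two.

Going by these compounds, it remains open whether an unsubstituted phenyl, or a phenyl carrying methoxy or trifluoromethyl in place of fluoro, would follow compound 3 or stay level with compound 1 and compound 2. Also open, on these data alone, is whether a longer chain at this place would keep the number of compound 3.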